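The source may report more compounds than this note shows. Statements on the series, on what has been measured and on what is new or still open speak of the compounds shown alone.

Compound 3 `CS(=O)(=O)c1ccc(N2CCc3c(OC4CCN(C(=O)OCCF)CC4)ncnc32)c(F)c1` gives 501 nM in a functional assay on CHO-K1 cells for agonist activity at Glucose-dependent insulinotropic receptor (Homo sapiens), read by a luciferase reporter, with a stated time of 5 h (a higher number here means that more compound is needed for the effect, a lower number that less compound is needed), the highest number among the three measured compounds; compound 1 `CC(C)(C)OC(=O)N1CCC(Oc2ncnc3c2CCN3c2ccc(S(C)(=O)=O)cc2F)CC1` gives 20 nM and compound 2 `CCCCOC(=O)N1CCC(Oc2ncnc3c2CCN3c2ccc(S(C)(=O)=O)cc2F)CC1` gives 50.1 nM. Compound 4 `CSC(=O)N1CCC(Oc2ncnc3c2CCN3c2ccc(S(C)(=O)=O)cc2F)CC1` differs from compound 3 by methylsulfanyl in place of 2-fluoroethoxy on a carbonyl carbon. Among the measured compounds shown here, no measured step replaces the oxygen on the carbonyl carbon, so the closest guidance comes from changes of the group on that oxygen: a 2.5-fold higher number from compound 1 to compound 2 (0.40 log units; beyond the scatter), a 25-fold higher number from compound 1 to compound 3 (1.40 log units; beyond the scatter) and a 10-fold higher number from compound 2 to compound 3 (1.00 log units; beyond the scatter), showing that this position can shift this assay widely. From the compounds shown here alone, because of a 10-fold higher number from compound 2 to compound 3 (1.00 log units; beyond the scatter), removal of the fluorine is expected to bring a modest improvement, a 2.0-fold lower number from compound 3 to compound 4 (0.30 log units; within the scatter), though the sulfur is untested. Compound 4 is therefore estimated at 250 nM, within 60 nM to 1000 nM.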

Compound 4, half-maximal effective concentration: 251 nM
Compound 4: middle estimate off by 1.0-fold (0.00 log units), on the low side; the measured number falls inside the stated range.
By their numbers in this assay, from the lowest: compound 1; then compound 2; then compounds 4 and 3 (each within the scatter of the next).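

Methylsulfanyl on the carbonyl carbon is the first group shown there that is joined through sulfur rather than oxygen, and in this assay the change from 2-fluoroethoxy gives a 2.0-fold lower number from compound 3 to compound 4 (0.30 log units; within the scatter) and so separates neither compound from the other. The larger oxygen-linked groups keep the lower numbers, with a 5.0-fold higher number from compound 2 to compound 4 (0.70 log units; beyond the scatter) and a 13-fold higher number from compound 1 to compound 4 (1.10 log units; beyond the scatter) showing that this sulfur-linked group does not match them. No measured evidence accounts for these differences. The compounds shown leave open whether tert-butylsulfanyl or butylsulfanyl on the carbonyl carbon would track their oxygen-linked counterparts, and how an amine at that place would compare.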